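Extending the Side Chain with a Methylpiperazine Group

The compounds below may be only part of what the source reports. "The series", "measured", "known", "first", "only" and "open" are said of these compounds alone.

Compound 1 `CCn1c(N)c(-c2nc3ccccc3[nH]2)c2nc(C#N)c(C#N)nc21` gives, in a functional assay on cells (Homo sapiens) for antiproliferative activity, read by MTT assay, with a stated time of 48 h (on this read-out higher numbers stand for weaker inhibition and lower numbers for stronger inhibition), a value of > 50000 nM, which is a limit of the assay.
Compound 2 `CN1CCN(CCn2c(N)c(-c3nc4ccccc4[nH]3)c3nc(C#N)c(C#N)nc32)CC1` gives 9110 nM in this assay.
Compound 3 `N#Cc1nc2c(-c3nc4ccccc4[nH]3)c(N)n(CCO)c2nc1C#N` gives > 50000 nM in this assay, again a limit of the assay.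

Compound 3 therefore stands at the limit of > 50000 nM in this assay, at which 2 of the 3 values shown sit, not at a number. Compound 4 `CN1CCN(CCCn2c(N)c(-c3nc4ccccc4[nH]3)c3nc(C#N)c(C#N)nc32)CC1` differs from it by (4-methylpiperazin-1-yl)methyl in place of hydroxy on a saturated chain carbon, two bonds along the chain from an aromatic nitrogen. Going by the values given here, two measured steps bear on this: an at least 5.4-fold lower number from compound 1 to compound 2 (0.73 log units; beyond the scatter) and an at least 5.4-fold higher number from compound 2 to compound 3 (0.73 log units; beyond the scatter), whereas a step that the two limits leave unreadable from compound 1 to compound 3. In this assay, a step of at least modest size toward lower numbers is therefore expected, roughly an at least 5.5-fold lower number from compound 3 to compound 4 (0.74 log units; beyond the scatter). Compound 4 is estimated at 9000 nM, within the range 3000 nM to 30000 nM.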

Compound 4, half-maximal inhibitory concentration: 4520 nM
Estimate against measurement, compound 4: 2.0-fold (0.30 log units) above, within the range that was stated.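

In this assay the 3-(4-methylpiperazin-1-yl)propyl chain of compound 4 gives a large step, an at least 11-fold lower number from compound 3 to compound 4 (1.04 log units; beyond the scatter), and an equally large one, an at least 11-fold lower number from compound 1 to compound 4 (1.04 log units; beyond the scatter). Both steps start from a limit of the assay, so their full size cannot be read: the limit of > 50000 nM in this assay, at which 2 of the 4 values shown sit. Putting (4-methylpiperazin-1-yl)methyl in place of 4-methylpiperazin-1-yl gives only a 2.0-fold lower number from compound 2 to compound 4 (0.30 log units; within the scatter), so the two chains bearing this ring cannot be told apart here.

From the compounds shown here alone, whether a morpholine, a dimethylamino group or a longer chain would serve in this place stays open.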